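Chloroacetamide to acrylamide: expected cell tolerance

The source may report more compounds than this note shows. Statements on the series, on what has been measured and on what is new or still open speak of the compounds shown alone.

Compound 1 `Cc1c(Oc2ccccc2OCCn2ccc(=O)[nH]c2=O)cc(Cl)c2ccc(C#N)cc12` and compound 2 `Cc1c(Oc2ccccc2OCCn2ccc(=O)[nH]c2=O)cc(N(C)C(=O)CCl)c2ccc(C#N)cc12` share one core and differ at a single aromatic carbon, where compound 2 carries ((chloromethyl)carbonyl)(methyl)amino in place of chloro. In a toxicity assay on MT2 cells (Homo sapiens) for cytotoxicity (a lower number here means that less compound is tolerated, a higher number that more compound is tolerated), compound 1 gives no number but only a limit, > 100000 nM (the limit of > 100000 nM in this assay, at which 1 of the 2 values shown sits). In this assay, among the measured compounds shown here, compound 2 gives 32000 nM, the only real number among the two values shown. That exchange gave an at least 3.1-fold lower number from compound 1 to compound 2 (0.49 log units; beyond the scatter).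

Compound 3 `C=CC(=O)N(C)c1cc(Oc2ccccc2OCCn2ccc(=O)[nH]c2=O)c(C)c2cc(C#N)ccc12` is not yet measured. Compared with compound 2 it differs by vinyl in place of chloromethyl on a carbonyl carbon, that is, vinylcarbonyl in place of (chloromethyl)carbonyl on the amide-type nitrogen. For the measured compounds named here, no measured step touches this carbonyl carbon; the only known step, from chloro to the acetamide, concerns a different place and offers no guide to the direction here. For compound 3 the expected step is therefore a 1.3-fold higher number from compound 2 to compound 3 (0.10 log units; within the scatter), within the scatter. In this assay compound 3 is estimated at 40000 nM, with a range from 15000 nM to 100000 nM.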

Compound 3, half-maximal cytotoxic concentration: 32000 nM
Compound 3: the middle estimate sits 1.3-fold (0.10 log units) above what was measured; the measured number falls inside the stated range.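

In this assay, among the compounds shown here, the exchange of chloromethyl for vinyl on the carbonyl carbon gives no change at the digits printed from compound 2 to compound 3 (within the scatter), the first reading at this position: these two groups, each of two heavy atoms, cannot be told apart in this assay. The second new step reads an at least 3.1-fold lower number from compound 1 to compound 3 (0.49 log units; beyond the scatter), which puts a second amide on the aromatic carbon beyond the scatter from chloro, and it matches what the chloromethyl amide showed earlier. Compound 1 has a limit and not a number, so this step gives only a minimum size: the limit of > 100000 nM in this assay, at which 1 of the 3 values shown sits.

Two groups on one carbonyl carbon cannot show whether any other group there would shift the tolerated concentration, and a plain ethyl group or a longer chain ending in a dimethylamine would test this. As far as these compounds go, it also stays open which part of the amide goes with the step away from chloro, and a simple methylamine on the same aromatic carbon, with no carbonyl at all, would help to separate the nitrogen from the acyl part.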